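Working notes: tolerated concentration across three compounds

The source may report more compounds than this note shows. Statements on the series, on what has been measured and on what is new or still open speak of the compounds shown alone.

Values in an ADME assay on CHO cells (Cricetulus griseus) for cytotoxicity, read by MTT assay; a higher number here means that more compound is tolerated, a lower number that less compound is tolerated:
- compound 1 `Fc1ccc(-c2nc3c(N4CCCNCC4)nccc3[nH]2)cc1F`: 7200 nM
- compound 2 `NC1CCN(c2nccc3[nH]c(-c4ccc(F)c(F)c4)nc23)CC1`: 8200 nM

Compound 2 and compound 1 sit within the scatter of each other. Compound 3 `CN1CCN(C(=O)C2CCN(c3nccc4[nH]c(-c5ccc(F)c(F)c5)nc34)CC2)CC1` has (4-methylpiperazin-1-yl)carbonyl in place of amino on a saturated ring carbon. Going by the values given here, the only measured step, a 1.1-fold higher number from compound 1 to compound 2 (0.06 log units; within the scatter), lies within the scatter and concerns a different replacement, so it offers weak guidance. Among the compounds with values here, no measured step covers this change. No step beyond the scatter is therefore expected in this assay, in either direction. The estimated step is a 1.1-fold higher number from compound 2 to compound 3 (0.04 log units; within the scatter). For compound 3 the expected value is 9000 nM, with an estimated range of 3000 nM to 30000 nM.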

Compound 3, half-maximal cytotoxic concentration: > 50000 nM
Compound 3 ended at the assay's limit; the forecaster's own chance of this, stated with the estimate: 10%; at least 5.5-fold (0.74 log units) between middle value and limit.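

In this assay, (4-methylpiperazin-1-yl)carbonyl in place of amino on the saturated ring carbon gives an at least 6.0-fold higher number from compound 2 to compound 3 (0.78 log units; beyond the scatter), the only step shown that lies beyond the scatter. The group on this carbon can therefore change the tolerated concentration, which the earlier step, a 1.1-fold higher number from compound 1 to compound 2 (0.06 log units; within the scatter), did not show. The value of compound 3 is a limit of the assay, not a number: the limit of > 50000 nM in this assay, at which 1 of the 3 values shown sits.

Going by these compounds, how far compound 3 truly lies from compound 2 stays open. Also open, on these data alone, is which part of the entering group carries the step, and a carboxylic acid or a primary amide on this carbon would separate the carbonyl from the piperazine ring.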